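The source may report more compounds than this note shows. Statements on the series, on what has been measured and on what is new or still open speak of the compounds shown alone.

Among the measured compounds shown here, in an ADME assay on L132 cells (Homo sapiens) for cytotoxicity, read by MTT assay, with a stated time of 72 h (a lower number here means a stronger inhibitor, a higher number a weaker inhibitor), compound 3 (`COc1ccc(C2=C(c3cc(OC)c(OC)c(OC)c3)C(=O)C(O[SiH2]C(C)(C)C)C2)cc1`) gives 9 ug/mL, the only true number so far. Compound 2 (`COc1ccc(C2=C(c3cc(OC)c(OC)c(OC)c3)C(=O)C(O)C2)cc1`) gives < 1 ug/mL, which is a limit of the assay. Compound 1 (`COc1ccc(C2=C(c3cc(OC)c(OC)c(OC)c3)C(=O)C(OC(C)=O)C2)cc1OC(C)C`) gives > 100 ug/mL, also a limit. Compound 4 (`COc1ccc(C2=C(c3cc(OC)c(OC)c(OC)c3)C(=O)C(O[SiH2]C(C)(C)C)C2)cc1OC(C)C`) differs from compound 3 by isopropoxy in place of hydrogen on an aromatic carbon. For the measured compounds named here, the one measured step, an at least 9.0-fold higher number from compound 2 to compound 3 (0.95 log units; beyond the scatter), changes the group on the oxygen and not this aromatic site, so it offers no direct guide. Only compound 1, at its limit of > 100 ug/mL, carries the 3-isopropoxy-4-methoxyphenyl group, and it differs elsewhere too. That limit points to a moderate rise, and the expected change is a 2.8-fold higher number from compound 3 to compound 4 (0.44 log units; beyond the scatter) in this assay. Compound 4 is expected at 25 ug/mL, with an estimated range of 6 ug/mL to 100 ug/mL.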

Compound 4, half-maximal inhibitory concentration: 7 ug/mL
For compound 4 the middle estimate is 3.6-fold (0.55 log units) above the measured one; the measured number falls inside the stated range.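

In this assay, isopropoxy in place of hydrogen on this aromatic carbon, ortho to a methoxy group, gives a 1.3-fold lower number from compound 3 to compound 4 (0.11 log units; within the scatter), so the change does not separate compound 4 from compound 3 when the silicon-bearing group sits on the oxygen. With the 3-isopropoxy-4-methoxyphenyl group common to both, changing the group on that oxygen gives an at least 14-fold lower number from compound 1 to compound 4 (1.15 log units; beyond the scatter), so the isopropoxy group alone does not go with the high reading. The number for compound 1 is a limit: the limit of > 100 ug/mL in this assay, at which 1 of the 4 values shown sits.

On these data alone, how isopropoxy behaves alongside the free hydroxyl of compound 2 remains open. So does whether an amine or a longer chain on this aromatic carbon would move the number beyond the scatter.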